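One added group on compound 3

This account rests on a few compounds, and the source may have more. Where it says the series, first, only, none or still open, it means among the compounds named here.

In an ADME assay on microsomes from liver (Rattus norvegicus) for metabolic stability, read by LC-MS, with a stated time of 30 min, tested at 1 uM (on this read-out higher numbers stand for a more stable compound and lower numbers for a less stable compound), compound 3 `CCNCc1cc(Cl)cc(Nc2nc3cc(F)c(F)cc3[nH]2)c1O` gives > 99%, which is a limit of the assay and not a number. Compound 3 therefore stands at the limit of > 99% in this assay, at which 1 of the 3 values shown sits.

Compound 4 `CCNCc1cc(Cl)cc(Nc2nc3cc(F)c(F)cc3n2Cc2ccc(C(F)(F)F)cc2)c1O` is made from compound 3 by one structural change: 4-(trifluoromethyl)benzyl in place of hydrogen on an aromatic nitrogen. In words, 4-(trifluoromethyl)benzyl takes the place of hydrogen on an aromatic nitrogen.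

Within the data shown here, no measured pair of compounds shows this change alone, so the expectation rests on two compounds that carry the same group but also differ from compound 4 elsewhere. Compound 1 `CC(C)(C)NCc1cc(Cl)cc(Nc2nc3cc(F)c(F)cc3n2Cc2ccc(C(F)(F)F)cc2)c1O` gives 94% in this assay. Compound 2 `CCNCc1cc(C)cc(Nc2nc3ccccc3n2Cc2ccc(C(F)(F)F)cc2)c1O` gives 51%. Both values leave room beneath the limit, and they lie far apart, so a moderate downward move is expected, with wide uncertainty. The estimated step is a number at least 23 percentage points lower from compound 3 to compound 4 (beyond the scatter).

For compound 4, the estimated value is 76%, with an expected range from 52% to 94%.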

Compound 4, percent of the compound remaining: 98%
For compound 4 the middle estimate is 22 percentage points below the measured one, outside the stated range (above it).
By their numbers in this assay, from the lowest: compound 2; then compounds 1 and 4 (each within the scatter of the next). At a limit, above all of these: compound 3.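

In this assay, among these compounds, the earlier compounds offered no direct reading of 4-(trifluoromethyl)benzyl in place of hydrogen on this aromatic nitrogen, and the step now reads as a number at least 1 percentage points lower from compound 3 to compound 4 (that floor lies within the scatter). The value of compound 3 is a limit of the assay and not a number, so the real size of this step cannot be read: the limit of > 99% in this assay, at which 1 of the 4 values shown sits. With this group in place, ethyl in place of tert-butyl on the amine nitrogen gives a number 4 percentage points higher from compound 1 to compound 4 (within the scatter).

Compound 2 differs from compound 4 in more than one place, so the compounds shown do not tell which difference goes with the value of compound 2, 51%. Also open, as far as these compounds go, is how a methyl group or a benzyl without trifluoromethyl would read on the same aromatic nitrogen.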